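A few compounds are considered here, and "the series" means these few. Any claim that something is new, unique, unknown or untested is made for them only; others in the source may bear on it.

Of the compounds shown here, three built around a shared core have been tested in a functional assay on SK-BR-3 cells (Homo sapiens) for antiproliferative activity; on this read-out higher numbers stand for weaker inhibition and lower numbers for stronger inhibition. Compound 1 `C=CCc1cc(C(=O)Nc2cc3ccc(OC4CCN(C)CC4)c(C)c3oc2=O)ccc1OC(C)=O` gives 2260 nM. Compound 2 `C=CCc1cc(C(=O)Nc2cc3ccc(OC4CCN(C)CC4)c(C)c3oc2=O)ccc1O` differs from compound 1 in one spot: hydrogen in place of acetyl on an oxygen on an aromatic ring. That change left the result nearly unmoved, as in this assay compound 2 gives 2430 nM, and the step is a 1.1-fold higher number from compound 1 to compound 2 (0.03 log units; within the scatter). Compound 3 `COc1cccc(-c2cc(C(=O)Nc3cc4ccc(OC5CCN(C)CC5)c(C)c4oc3=O)ccc2OC(C)=O)c1` carries a different group on the core: 3-methoxyphenyl in place of allyl on an aromatic carbon. In this assay compound 3 gives 920 nM, a modest improvement: a 2.5-fold lower number from compound 1 to compound 3 (0.39 log units; beyond the scatter).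

Compound 4 `COc1cccc(-c2cc(C(=O)Nc3cc4ccc(OC5CCN(C)CC5)c(C)c4oc3=O)ccc2O)c1` has not yet been measured. It is related to compound 3 exactly as compound 2 is related to compound 1: hydrogen in place of acetyl on an oxygen on an aromatic ring. The spot where the change is made is described in the same words for both pairs, so this is the same change, now made on the core that carries the 3-methoxyphenyl group instead of the allyl group. For the measured compounds named here, the one time this change has been measured, from compound 1 to compound 2, the step was a 1.1-fold higher number from compound 1 to compound 2 (0.03 log units; within the scatter), too small to count as a real shift. The expectation for compound 4 rests on that single pair, and a step of about a 1.1-fold higher number from compound 3 to compound 4 (0.04 log units; within the scatter) is expected, which would leave compound 4 close to compound 3. In this assay compound 4 is estimated at 1000 nM, with a likely range from 450 nM to 2200 nM. Going by the values given here, only one earlier example of the change exists, and on a different core, so the range is kept wide.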

Compound 4, half-maximal inhibitory concentration: 860 nM
Estimate against measurement, compound 4: 1.2-fold (0.07 log units) above; the range from low to high includes it.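

Replacing acetyl with hydrogen on the oxygen again leaves the result in place in this assay, with a 1.1-fold lower number from compound 3 to compound 4 (0.03 log units; within the scatter), so the acetoxy to hydroxy change reads the same whether the aromatic carbon carries allyl or 3-methoxyphenyl: the same change on two cores in this assay, a 1.1-fold higher number (0.03 log units; within the scatter) from compound 1 to compound 2 and a 1.1-fold lower number (0.03 log units; within the scatter) from compound 3 to compound 4, 1.2-fold (0.06 log units) apart, within the scatter of two such steps. The other change also carries over, since 3-methoxyphenyl in place of allyl, already a modest gain on the acetylated compounds, is again a modest gain on the hydroxy compounds, with a 2.8-fold lower number from compound 2 to compound 4 (0.45 log units; beyond the scatter), and the two gains agree: the same change on two cores in this assay, a 2.5-fold lower number (0.39 log units; beyond the scatter) from compound 1 to compound 3 and a 2.8-fold lower number (0.45 log units; beyond the scatter) from compound 2 to compound 4, 1.2-fold (0.06 log units) apart, within the scatter of two such steps. Within these four compounds, then, each change has much the same size whichever form the other spot takes, but this rests on just two pairs per change in a single assay, and it neither explains why the numbers move as they do nor shows that the agreement would extend to other groups.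

What the compounds shown leave open is how other groups would behave at these two spots, such as a plain phenyl or a longer chain on the aromatic carbon, or a methyl or benzoyl on the oxygen. From the compounds shown here alone, it also remains open whether the hydroxy and acetoxy forms would stay this close with such groups in place.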